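The source may report more compounds than this note shows. Statements on the series, on what has been measured and on what is new or still open speak of the compounds shown alone.

Measured compounds in an assay on lysate for inhibition of phosphatidylcholine:ceramide cholinephosphotransferase 2 (Homo sapiens), read by HPLC, with stated times of 30 min and 2 h; on this read-out lower numbers stand for stronger inhibition and higher numbers for weaker inhibition:
compound 1 `O=C(NC1CCCCC1)c1ccccc1OCc1ccccc1` — 43400 nM
compound 2 `O=C(Nc1cccnc1)c1ccccc1OCc1ccccc1` — 3200 nM

For the measured compounds named here, compound 2 gives the lower of the two numbers in this assay; the only step between the measured compounds, a 14-fold lower number from compound 1 to compound 2 (1.13 log units; beyond the scatter), separates it from compound 1 and lies beyond the scatter.

Compound 3 `O=C(Nc1cccnc1)c1ccccc1OCc1ccccc1F` has not been measured. It differs from compound 2 by fluoro in place of hydrogen on an aromatic carbon. Going by the values given here, the single measured step concerns the group on the amide-type nitrogen, not the benzyl ring, so no step on record bears on this change; how this assay responds to substitution on the benzyl ring is unknown from these two compounds. With no guide either way, the expectation is a step of no size beyond the scatter, a 1.2-fold lower number from compound 2 to compound 3 (0.09 log units; within the scatter).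

Compound 3 is therefore estimated at 2600 nM in this assay, with a range of 900 nM to 8000 nM.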

Compound 3, half-maximal inhibitory concentration: 3500 nM
The estimate for compound 3 lay 1.3-fold (0.13 log units) below the measured number, within the range that was stated.
By their numbers in this assay, from the lowest: compounds 2 and 3 (each within the scatter of the next); then compound 1.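

In this assay fluoro in place of hydrogen on an aromatic carbon, ortho to a large group, gives a 1.1-fold higher number from compound 2 to compound 3 (0.04 log units; within the scatter) and so does not separate 2-fluorobenzyl from benzyl at this place. For the compounds shown here, this is the first reading on the benzyl side of the series, since the earlier step concerned only the group on the amide-type nitrogen, and it shows that a single fluoro here leaves the number within the scatter. No measurement at hand explains this flat step.

On these data alone, whether a larger group at this place, such as methoxy, trifluoromethyl or an amine, would also stay within the scatter remains open. Also open, as far as these compounds go, are fluoro elsewhere on this ring and whether the same change would read alike with cyclohexyl on the amide-type nitrogen.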